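Fluoro in place of methyl: the next measurement

The compounds below may be only part of what the source reports. "The series", "measured", "known", "first", "only" and "open" are said of these compounds alone.

Measured in a functional assay on HeLa cells (Homo sapiens) for cytotoxicity, read by MTT assay, with a stated time of 48 h; on this read-out higher numbers stand for weaker inhibition and lower numbers for stronger inhibition:

compound 1 `OC[C@@H]1C[C@H](CO)[C@@H]2C(c3ccc(Cl)cc3)=NO[C@H]12`: > 50 ug/mL
compound 2 `Cc1ccc(C2=NO[C@@H]3[C@H](CO)C[C@H](CO)[C@H]23)cc1`: 26.5 ug/mL
compound 3 `OC[C@@H]1C[C@H](CO)[C@@H]2C(c3ccc4ccccc4c3)=NO[C@H]12`: 24.5 ug/mL

Compound 1 gives > 50 ug/mL, which is a limit of the assay and not a number. Among the measured compounds shown here, only two compounds therefore carry true numbers. Compound 2 stands at 26.5 ug/mL, within the scatter of compound 3 at 24.5 ug/mL, so neither can be ranked above the other.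

The account now follows the step to compound 4 `OC[C@@H]1C[C@H](CO)[C@@H]2C(c3ccc(F)cc3)=NO[C@H]12`, which has not yet been measured. The change is fluoro in place of methyl on an aromatic carbon, para to a large group.

For the measured compounds named here, one measured step bears on it, the replacement of chloro by methyl on an aromatic carbon, an at least 1.8-fold lower number from compound 1 to compound 2 (0.27 log units; that floor lies within the scatter). Because that step rests on a limit, it gives only a floor and no true size. It does suggest that losing the methyl could move the number upward, towards weaker inhibition, though not by much. The expected step is therefore small and not beyond the scatter, a 1.3-fold higher number from compound 2 to compound 4 (0.12 log units; within the scatter). A limit instead of a number would not be surprising.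

The estimate for compound 4 is 35 ug/mL, with an expected range of 16 ug/mL to 75 ug/mL.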

Compound 4, half-maximal inhibitory concentration: > 50 ug/mL
Compound 4 was reported as a limit (the forecaster's own chance of this, stated with the estimate: 30%); middle value at least 1.4-fold (0.15 log units) away from the limit.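

In this assay compound 4 gives > 50 ug/mL, which is a limit of the assay and not a number. Fluoro in place of methyl on this aromatic carbon, para to a large group, gives an at least 1.8-fold higher number from compound 2 to compound 4 (0.27 log units; that floor lies within the scatter), and this figure is a floor, not a true size. The steps between compound 1 and compound 4 cannot be read, so chloro and fluoro cannot be ranked against each other, but the new result shows that the limit is not confined to chloro, and among the compounds with one small group at this position, only the methyl of compound 2 gives a true number, while chloro and fluoro both end at the same limit: the limit of > 50 ug/mL in this assay, at which 2 of the 4 values shown sit.

The compounds shown leave open how large the true step from methyl to fluoro is, since only its floor can be read. They also leave open whether an ethyl group, a methoxy group or an amine at this position would give a true number, and how such a compound would compare with compound 2 and compound 3.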